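Series notes: from compound 3 toward compound 4

This account rests on a few compounds, and the source may have more. Where it says the series, first, only, none or still open, it means among the compounds named here.

Measured so far:
Compound 1, `Cc1cc(=O)[nH]c(=O)n1COC(CO)CO`, in a functional assay on MCF7 cells (Homo sapiens) for inhibition, read by MTT assay, with a stated time of 72 h (a higher number here means a weaker inhibitor, a lower number a stronger inhibitor), gives > 100000 nM, which is a limit of the assay and not a number.
Compound 2, `NCC(=O)Nc1c[nH]c(=O)[nH]c1=O`, gives > 100000 nM in this assay; this too is a limit.
Compound 3, `O=c1ccn(COC(CO)CO)c(=O)[nH]1`, gives > 100000 nM in this assay, again a limit only.

Compound 3 therefore stands nowhere readable on the scale: only a limit is known for it, and the two other values shown are limits as well (the limit of > 100000 nM in this assay, at which 3 of the 3 values shown sit). Within the data shown here, the one single-change step among the measured compounds, a step that the two limits leave unreadable from compound 1 to compound 3, hydrogen in place of methyl on an aromatic carbon, cannot be read because both ends sit at the limit (the limit of > 100000 nM in this assay, at which 3 of the 3 values shown sit).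

Compound 4, `Nc1cn(COC(CO)CO)c(=O)[nH]c1=O`, differs from compound 3 by amino in place of hydrogen on an aromatic carbon, on a six-membered aromatic ring with two nitrogens, two atoms from the ring nitrogen.

Among the measured compounds shown here, no measured step bears readably on this change. With all three shown values at the limit (the limit of > 100000 nM in this assay, at which 3 of the 3 values shown sit), the expectation for compound 4 is that it also reports a limit, so the step of a number no higher from compound 3 to compound 4 (the limit leaves the size open) is expected to be none beyond the scatter. Compound 4 is estimated at 100000 nM, within 30000 nM to 300000 nM.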

Compound 4, half-maximal inhibitory concentration: > 100000 nM
Compound 4: no number, only a limit; the forecaster's own chance of this, stated with the estimate: 85%; the middle value sits exactly at the limit.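

Among these compounds, compound 4 reports only a limit of the assay, as compound 3 does, so the step between compound 3 and compound 4 cannot be read and no new step comes from this result: the limit of > 100000 nM in this assay, at which 4 of the 4 values shown sit. The compounds shown leave open what size of effect, if any, amino in place of hydrogen on an aromatic carbon has in this assay, and whether any change to the shared core gives a readable value there.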